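This account rests on a few compounds, and the source may have more. Where it says the series, first, only, none or still open, it means among the compounds named here.

Measured so far in an ADME assay on NCM460 cells (Homo sapiens) for cytotoxicity, read by MTT assay, with a stated time of 72 h; on this read-out higher numbers stand for weaker inhibition and lower numbers for stronger inhibition:

- compound 1 `CCOc1ccc(NC(=O)c2cccc(/C=C3\CC(=O)N(c4ccccc4)C3=O)c2)cc1`: > 100000 nM, a limit of the assay.
- compound 2 `Cc1ccc(NC(=O)c2cccc(/C=C3\CC(=O)N(c4ccccc4)C3=O)c2)cc1C`: > 100000 nM, a limit of the assay.
- compound 3 `O=C(Nc1ccc(Cl)cc1)c1cccc(/C=C2\CC(=O)N(Cc3ccccc3)C2=O)c1`: > 100000 nM, a limit of the assay.

Compound 1 stands only at a limit in this assay, and the two other values shown are limits as well. Among the measured compounds shown here, the single step between measured compounds that differ in one place, a step that the two limits leave unreadable from compound 1 to compound 2, is therefore unreadable in size; all that is known is the limit of > 100000 nM in this assay, at which 3 of the 3 values shown sit.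

Compound 4 `O=C(Nc1ccc(Cl)cc1)c1cccc(/C=C2\CC(=O)N(c3ccccc3)C2=O)c1` differs from compound 1 in one place: chloro in place of ethoxy on an aromatic carbon. For the measured compounds named here, no measured step bears directly on this change. Compound 3, which carries the same chloro group on the same aromatic carbon together with a benzyl group on the imide nitrogen, also sits at the limit. With every value at the limit, no step beyond the scatter in this assay can be expected, and the step that the limit leaves unreadable from compound 1 to compound 4 is expected to be none beyond the scatter. Compound 4 is estimated at 150000 nM in this assay, with a range from 30000 nM to 1000000 nM.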

Compound 4, half-maximal inhibitory concentration: > 100000 nM
Compound 4 was reported as a limit (the forecaster's own chance of this, stated with the estimate: 85%); the middle value does not contradict the limit.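

No step can be read among compound 1, compound 2, compound 3 and compound 4, as all four stand at a limit of the assay: the limit of > 100000 nM in this assay, at which 4 of the 4 values shown sit.

The compounds shown leave open whether any change to the shared core would give a numerical value in this assay.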